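A few compounds are considered here, and "the series" means these few. Any claim that something is new, unique, unknown or untested is made for them only; others in the source may bear on it.

Measured compounds:
compound 1 `COc1ccc(C)cc1NC(=O)CSc1nnc(-c2ccoc2C)n1Cc1ccco1` 2510 nM
compound 2 `Cc1occc1-c1nnc(SCC(=O)Nc2ccc(F)c(Cl)c2)n1Cc1ccco1` 1000 nM
compound 3 `Cc1occc1-c1nnc(SCC(=O)Nc2cccc(Cl)c2)n1Cc1ccco1` 2000 nM

In a functional assay on CHO cells for antagonist activity at Orexin/Hypocretin receptor type 1 (Homo sapiens), read by FLIPR and calcium flux (a lower number here means a stronger inhibitor, a higher number a weaker inhibitor), compound 1 gives 2510 nM, the highest of the three numbers. Compound 3 stands nearest to it a 1.3-fold lower number from compound 1 to compound 3 (0.10 log units; within the scatter), and compound 2 furthest a 2.5-fold lower number from compound 1 to compound 2 (0.40 log units; beyond the scatter); between compound 2 and compound 3 the step is a 2.0-fold higher number from compound 2 to compound 3 (0.30 log units; within the scatter).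

Compound 4 `Cc1occc1-c1nnc(SCC(=O)NN2CCc3ccccc32)n1Cc1ccco1` is the compound not yet measured. It differs from compound 1 in one place: 2,3-dihydro-1H-indol-1-yl in place of 2-methoxy-5-methylphenyl on an amide-type nitrogen.

For the measured compounds named here, none of the measured steps tries this kind of change. Each of them exchanges one six-membered aromatic ring for another on the amide-type nitrogen, and the largest of them, a 2.5-fold lower number from compound 1 to compound 2 (0.40 log units; beyond the scatter), is only modest, while the other two stay within the scatter. Going by the values given here, the group that enters in compound 4 has no counterpart among compounds 2 and 3, so the measured steps give no direction for it. On that basis compound 4 is expected to land close to compound 1, with an estimated step of a 1.2-fold higher number from compound 1 to compound 4 (0.08 log units; within the scatter) that carries wide uncertainty. The estimate for compound 4 is therefore 3000 nM, expected to fall between 900 nM and 10000 nM.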

Compound 4, inhibition constant: > 15800 nM
Compound 4: no number, only a limit (the forecaster's own chance of this, stated with the estimate: 25%); at least 5.2-fold (0.72 log units) between middle value and limit.
By their numbers in this assay, from the lowest: compounds 2, 3 and 1 (each within the scatter of the next, the first and the last beyond it). At a limit, above all of these: compound 4.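

In this assay compound 4 gives > 15800 nM, which is a limit of the assay and not a number. The amide-type nitrogen had tolerated one substituted phenyl in place of another with only modest steps, but it proves sensitive to 2,3-dihydro-1H-indol-1-yl: an at least 6.2-fold higher number from compound 1 to compound 4 (0.79 log units; beyond the scatter), an at least 7.9-fold higher number from compound 3 to compound 4 (0.89 log units; beyond the scatter) and an at least 15-fold higher number from compound 2 to compound 4 (1.19 log units; beyond the scatter). The groups exchanged between compound 1 and compound 4 match in heavy atoms, hydrogen-bond donors and hydrogen-bond acceptors, so these counts do not account for the step.

On these data alone, how far the value of compound 4 lies past its limit remains open. Also open, as far as these compounds go, is whether an open-chain methyl(phenyl)amino group on the same amide-type nitrogen would stay close to compound 1 or fall away like compound 4.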